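The source may hold more compounds than are shown below. What is called first, only, known or untested is meant among the compounds shown, and "the series" means these compounds.

Measured so far:
compound 1 `CNC(=O)c1cc(C(=O)N[C@H]2[C@@H]3C[C@H](O)C[C@@H]32)n([C@@H](C)c2cccc(Cl)c2)n1` — 8.3 mL/min
compound 2 `CNC(=O)c1cc(C(=O)N[C@H]2[C@@H]3COC[C@@H]32)c([C@@H](C)c2ccccc2)o1` — < 0.65 mL/min

Going by the values given here, in an ADME assay on cells (Hepatocyte, Canis lupus familiaris) for metabolic stability, read by LC-MS (on this read-out higher numbers stand for fast clearance and lower numbers for slow clearance), compound 1 gives 8.3 mL/min, the only number in the set. Compound 2 sits at a limit of this assay, (the limit of < 0.65 mL/min in this assay, at which 1 of the 2 values shown sits), which is not a number. Compound 3 `CNC(=O)c1cc(C(=O)N[C@H]2[C@@H]3C[C@@H](O)C[C@@H]32)n([C@@H](C)c2cccc(Cl)c2)n1` is not yet measured. How it differs from compound 1: the two compounds have the same atoms and bonds and differ only in configuration as drawn: 1 of 5 stereo elements differ; a stereocentre at a saturated ring carbon is drawn S in compound 1 and R in compound 3. Among the compounds with values here, no measured pair isolates this kind of change, so a step no larger than the scatter is expected, in no preferred direction. Compound 3 is estimated at 8 mL/min (range 3 mL/min to 20 mL/min), a step of a 1.0-fold lower number from compound 1 to compound 3 (0.02 log units; within the scatter).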

Compound 3, intrinsic clearance in a liver preparation (reported as CLH), per the amount of preparation that the assay uses: < 0.65 mL/min
Compound 3 gave a limit, no number (the forecaster's own chance of this, stated with the estimate: 5%); middle value at least 12-fold (1.09 log units) away from the limit.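

In this assay, changing a stereocentre at a saturated ring carbon from S to R gives an at least 12-fold lower number from compound 1 to compound 3 (1.10 log units; beyond the scatter), so the drawn configuration at this position alone can shift this read-out strongly. On these data alone, compound 3 gives a limit and not a number, so the full size of the step stays unknown: the limit of < 0.65 mL/min in this assay, at which 2 of the 3 values shown sit. The step can be assigned to this stereocentre because no atom or bond changes: the fact that compounds 1 and 3 differ only in the configuration as drawn.

As far as these compounds go, whether an amine on this saturated ring carbon would show the same dependence on configuration stays open. So does whether this step recurs on other cores.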